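A few compounds are considered here, and "the series" means these few. Any claim that something is new, unique, unknown or untested is made for them only; others in the source may bear on it.

The compounds share one core and differ only in the aryl group on the amine nitrogen. Compound 1 `CC1CC/C(=N\Nc2ccccc2F)c2ncc(C(=O)O)c(=O)n21` carries a 2-fluorophenyl there. In a functional assay on the whole organism for inhibition, with Rattus norvegicus as the target (a higher number here means that more compound is needed for the effect, a lower number that less compound is needed), compound 1 gives only a limit, > 1000 umol/kg, and no number. Compound 2 `CC1CC/C(=N\Nc2cccc(Br)c2)c2ncc(C(=O)O)c(=O)n21` carries a 3-bromophenyl. In this assay compound 2 likewise stands at a limit, > 320 umol/kg. Compound 3 `CC1CC/C(=N\Nc2ccc(O)cc2)c2ncc(C(=O)O)c(=O)n21` carries a 4-hydroxyphenyl, and in this assay compound 3 also gives a limit, > 100 umol/kg. Compound 2 thus stands at one of three limits set at different ceilings, (the limit of > 100 umol/kg in this assay, at which 1 of the 3 values shown sits), the limit of > 320 umol/kg in this assay, at which 1 of the 3 values shown sits, and (the limit of > 1000 umol/kg in this assay, at which 1 of the 3 values shown sits), none of which can be placed against another. The steps a step that the two limits leave unreadable from compound 1 to compound 2, a step that the two limits leave unreadable from compound 2 to compound 3 and a step that the two limits leave unreadable from compound 1 to compound 3 are therefore unreadable in size and direction.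

Compound 4 `CC1CC/C(=N\Nc2cccc(C(F)(F)F)c2)c2ncc(C(=O)O)c(=O)n21` differs from compound 2 by trifluoromethyl in place of bromo on an aromatic carbon. Going by the values given here, the only measured steps that bear on this change are the three just named, and none of them yields a size. No step beyond the scatter in this assay can be expected in either direction, and the likeliest outcome for compound 4 is once more a limit. Compound 4 is estimated at 1000 umol/kg, between 200 umol/kg and 5000 umol/kg, which means an expected step that the limit leaves unreadable from compound 2 to compound 4.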

Compound 4, dose for 50% inhibition: > 1000 umol/kg
Compound 4: only a limit was reported; the forecaster's own chance of this, stated with the estimate: 80%; the middle value lies on the limit itself.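

In this assay compound 4 gives only a limit, > 1000 umol/kg. Compound 2 also stands at a limit, so the step from compound 2 to compound 4 cannot be read in size or direction. The compounds shown leave open whether any of these aryl groups on the amine nitrogen gives a number rather than a limit in this assay.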